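The source may report more compounds than this note shows. Statements on the series, on what has been measured and on what is new or still open speak of the compounds shown alone.

Values in a functional assay on the whole organism with Mus musculus as the target, in the rotarod test; on this read-out lower numbers stand for an effect already at smaller amounts and higher numbers for an effect only at larger amounts of compound:
- compound 1 `NC(=O)/C=C1\CCc2c(F)cc(F)cc21`: 138 mg/kg
- compound 2 `O=C(/C=C1\CCc2c(F)cc(F)cc21)NC1CC1`: 62 mg/kg
- compound 3 `CC(C)NC(=O)/C=C1\CCc2c(F)cc(F)cc21`: not yet measured

In this assay, compound 2 holds the lower of the two numbers, at 62 mg/kg. The next change is isopropyl in place of cyclopropyl on an amide-type nitrogen. Among the measured compounds shown here, the only measured step that bears on it is a 2.2-fold lower number from compound 1 to compound 2 (0.35 log units; beyond the scatter), a modest one, which brought in the cyclopropyl. For the measured compounds named here, no measured step compares cyclopropyl with isopropyl directly, so no step beyond the scatter is expected, and the direction stays open. The expected step is a 1.0-fold higher number from compound 2 to compound 3 (0.02 log units; within the scatter). Compound 3 is expected at 65 mg/kg, with an estimated range of 35 mg/kg to 125 mg/kg.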

Compound 3, dose for half-maximal effect: 76 mg/kg
Estimate against measurement, compound 3: 1.2-fold (0.07 log units) below, within the range that was stated.
By their numbers in this assay, from the lowest: compounds 2, 3 and 1 (each within the scatter of the next, the first and the last beyond it).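

In this assay, isopropyl in place of cyclopropyl on the amide-type nitrogen gives a 1.2-fold higher number from compound 2 to compound 3 (0.09 log units; within the scatter), so the three-membered ring is not needed to keep the number at this level. Isopropyl in place of hydrogen gives a 1.8-fold lower number from compound 1 to compound 3 (0.26 log units; within the scatter), so this change alone does not clear the scatter, even though compounds 2 and 3 cannot be told apart. No measured evidence bears on why the two groups read alike.

Open, as far as these compounds go, is whether a longer chain such as n-butyl, or a cyclobutyl or tert-butyl group, on this nitrogen keeps that level. From the compounds shown here alone, a chain carrying a hydroxyl or an amine at this place is equally open.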